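The compounds below may be only part of what the source reports. "The series", "measured", "known", "first", "only" and "open" are said of these compounds alone.

Three compounds have been measured in an assay on isolated protein for displacement of a labelled ligand from metabotropic glutamate receptor 5 (Homo sapiens), with a stated time of 60 min, tested at 1 uM; on this read-out higher numbers stand for more inhibition at the one concentration tested (going by the name of the read-out) and lower numbers for less inhibition:

Compound 1 `COc1ccc2ncc(S(=O)(=O)c3ccc(C)c(Cl)c3)c(N3CCC(C)CC3)c2c1` gives 85%.
Compound 2 `COc1ccc2ncc(S(=O)(=O)c3ccc(Cl)cc3)c(N3CCC(C)CC3)c2c1` gives 91%.
Compound 3 `COc1ccc2ncc(S(=O)(=O)c3ccc(C)cc3)c(N3CCC(C)CC3)c2c1` gives 90%.

All three numbers sit close together. The step of a number 5 percentage points higher from compound 1 to compound 3 (within the scatter) and the step of a number 1 percentage points lower from compound 2 to compound 3 (within the scatter) are both within the usual scatter, so compound 3 cannot be told apart from compound 1 or compound 2 on these numbers, and the step of a number 6 percentage points higher from compound 1 to compound 2 (within the scatter) is likewise within the scatter.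

Compound 4 `COc1ccc2ncc(S(=O)(=O)c3cccc(C#N)c3)c(N3CCC(C)CC3)c2c1` differs from compound 3 by 3-cyanophenyl in place of 4-methylphenyl on a sulfonyl sulfur. The three measured steps all change the substituents on the ring attached to the sulfonyl sulfur, swapping chloro, methyl and hydrogen, and none of them moved the read-out beyond the scatter. As far as these compounds go, none involves a nitrile, so that change is untested here. Given that small changes on this ring have left the read-out flat, compound 4 is expected to stay near compound 3, with an expected step of a number 6 percentage points lower from compound 3 to compound 4 (within the scatter) that is not beyond the scatter, though a somewhat wider spread is allowed for the untested group. Compound 4 is therefore estimated at 84%, within the range 62% to 96%.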

Compound 4, a percentage reported as inhibition, at one concentration (the size of the read-out at that concentration, not a potency): 90%
The estimate for compound 4 lay 6 percentage points below the measured number, within the range that was stated.
By their numbers in this assay, from the lowest: compounds 1, 3, 4 and 2 (each within the scatter of the next).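

With 3-cyanophenyl on the sulfonyl sulfur, the read-out in this assay shows no change at the digits printed from compound 3 to compound 4 (within the scatter), along with a number 1 percentage points lower from compound 2 to compound 4 (within the scatter) and a number 5 percentage points higher from compound 1 to compound 4 (within the scatter). So the first nitrile in this set, on a ring carrying a single substituent in a different place from those of compound 2 and compound 3, leaves the read-out indistinguishable from the three earlier aryl groups. No measurement shown here explains why this change leaves the number flat.

As far as these compounds go, whether a carboxylic acid or an amine on this ring would hold the read-out as well remains open. A single tested concentration also leaves open whether these four compounds would differ in potency across a range of concentrations.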